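The source may report more compounds than this note shows. Statements on the series, on what has been measured and on what is new or still open speak of the compounds shown alone.

Compound 3 `O=C(Nc1cccc(-c2oc3cc(-c4ccc(F)cc4)ccc3c(=O)c2O)c1)c1ccc(C(F)(F)F)cc1` belongs to a small set of three amides that share one core and differ only in the aryl group attached to the carbonyl carbon. In a functional assay on HCC1937 cells (Homo sapiens) for antiproliferative activity, read by CCK-8 assay, with a stated time of 72 h (a lower number here means a stronger inhibitor, a higher number a weaker inhibitor), compound 3 gives 7350 nM. Compound 1 `COc1ccc(C(=O)Nc2cccc(-c3oc4cc(-c5ccc(F)cc5)ccc4c(=O)c3O)c2)cc1` gives 5490 nM, and compound 2 `Cc1ccccc1C(=O)Nc1cccc(-c2oc3cc(-c4ccc(F)cc4)ccc3c(=O)c2O)c1` gives 9900 nM. All three values lie within the usual scatter of one another, so compound 3 cannot be told apart from either neighbour on these numbers.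

Compound 4 `Cc1cc(C(=O)Nc2cccc(-c3oc4cc(-c5ccc(F)cc5)ccc4c(=O)c3O)c2)ccc1F` has not yet been measured. It differs from compound 3 in one place: 4-fluoro-3-methylphenyl in place of 4-(trifluoromethyl)phenyl on a carbonyl carbon.

Going by the values given here, two measured steps touch the same position. The exchange of methoxy for trifluoromethyl gave a 1.3-fold higher number from compound 1 to compound 3 (0.13 log units; within the scatter), and the exchange of the whole 2-methylphenyl for 4-(trifluoromethyl)phenyl gave a 1.3-fold lower number from compound 2 to compound 3 (0.13 log units; within the scatter). Neither change at this aryl group moved the number beyond the scatter, and the new 4-fluoro-3-methylphenyl group is of a similar kind to those already tried. The step to compound 4 is therefore expected to be a 1.1-fold lower number from compound 3 to compound 4 (0.02 log units; within the scatter), with no direction that can be trusted. Compound 4 is estimated to give 7000 nM in this assay, with a likely range from 3500 nM to 14000 nM.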

Compound 4, half-maximal inhibitory concentration: 5420 nM
Compound 4: the middle estimate sits 1.3-fold (0.11 log units) above what was measured; measured number inside the range.
By their numbers in this assay, from the lowest: compounds 4, 1, 3 and 2 (each within the scatter of the next).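

In this assay, 4-fluoro-3-methylphenyl in place of 4-(trifluoromethyl)phenyl on the carbonyl carbon gives a 1.4-fold lower number from compound 3 to compound 4 (0.13 log units; within the scatter), which lies within the usual scatter. Going by these compounds alone, the new group also stays within the scatter of the other two aryl groups, with a 1.8-fold lower number from compound 2 to compound 4 (0.26 log units; within the scatter) and a 1.0-fold lower number from compound 1 to compound 4 (0.01 log units; within the scatter), so a ring carrying both a fluorine and a methyl group now joins the 4-methoxyphenyl, 2-methylphenyl and 4-(trifluoromethyl)phenyl rings with no step here that can be told apart from repeat-measurement noise. With four aryl groups on the same amide, the compounds give no order among themselves at this position, and no measurement given here explains why the number stays so flat.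

All the compounds shown keep an aromatic carbon ring on the carbonyl carbon, so this flat picture holds only for that kind of group and for the shared core. Still open, on these data alone, is whether a carboxylic acid or an amine on this ring, or a longer alkyl chain in place of the ring, would move the number beyond the scatter.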